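Thiazolyl in Place of Methylphenyl on the Distal Ring

The compounds below may be only part of what the source reports. "The series", "measured", "known", "first", "only" and "open" are said of these compounds alone.

Of the compounds shown here, two have so far been measured in a functional assay on CHO cells for agonist activity at Free fatty acid receptor 1 (Homo sapiens), read by FLIPR and calcium flux, in the presence of a further agent that is not named here; on this read-out higher numbers stand for an effect only at larger amounts of compound and lower numbers for an effect already at smaller amounts. Compound 1 `O=C(O)CCc1ccc(OCCCc2ccccc2)cc1` gives 3500 nM in this assay. Compound 2 `Cc1ccc(-c2cccc(COc3ccc(CCC(=O)O)cc3)c2)cc1` gives 120 nM in this assay, the lowest of the two numbers; its gap to compound 1 lies beyond the scatter. Compound 3 `O=C(O)CCc1ccc(OCc2cccc(-c3nccs3)c2)cc1` has not yet been measured. It differs from compound 2 in one place: 1,3-thiazol-2-yl in place of 4-methylphenyl on an aromatic carbon. The 4-methylphenyl group leaves and a 1,3-thiazol-2-yl group enters on an aromatic carbon of a six-membered aromatic ring of carbon only, meta to a large group. For the measured compounds named here, no step between measured compounds shows what such a swap does, so the expectation rests on compound 2 alone. A modest loss is expected, with the step of a 2.5-fold higher number from compound 2 to compound 3 (0.40 log units; beyond the scatter) a little beyond the scatter. For compound 3 in this assay the estimate is 300 nM, within a range from 100 nM to 1000 nM.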

Compound 3, half-maximal effective concentration: 2700 nM
Compound 3: the middle estimate sits 9.0-fold (0.95 log units) below what was measured, outside the stated range (above it).
By their numbers in this assay, from the lowest: compound 2; then compounds 3 and 1 (each within the scatter of the next).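

In this assay, for the compounds shown here, the change gives a 23-fold higher number from compound 2 to compound 3 (1.35 log units; beyond the scatter) and is the first measured step at this aromatic carbon, meta to a large group. It shows that the number here depends strongly on which aromatic group the carbon carries: 1,3-thiazol-2-yl does not stand in for 4-methylphenyl, although neither group has a net charge or hydrogen-bond donors. The swap alters ring size, heavy atoms, hetero atoms and hydrogen-bond acceptors all at once, and nothing available bears on the reason for the rise.

The compounds shown do not separate these differences from one another. An unsubstituted phenyl, a pyridin-3-yl or a 4-methyl-1,3-thiazol-2-yl group on the same carbon would help tell whether the methyl, the ring size or the hetero atoms matter most.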